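The source may hold more compounds than are shown below. What is called first, only, known or untested is meant among the compounds shown, and "the series" means these compounds.

Measured in a functional assay on HUVEC cells (Homo sapiens) for antiproliferative activity, read by MTT assay, with a stated time of 24 h; on this read-out lower numbers stand for stronger inhibition and higher numbers for weaker inhibition:
Compound 1 `C=CCc1cc(-c2cc(F)cc(F)c2)ccc1O`: 80000 nM
Compound 2 `C=CCOc1ccc(-c2ccc(OC)cc2)cc1CC=C`: > 100000 nM, a limit of the assay

Compound 2 stands at the limit of > 100000 nM in this assay, at which 1 of the 2 values shown sits. Its reading is a limit and not a number, so it marks no exact starting point.

Compound 3 `C=CCc1cc(-c2ccc(OC)cc2)ccc1O` differs from compound 2 in one place: hydrogen in place of allyl on an oxygen on an aromatic ring. This is hydrogen in place of allyl on an oxygen on an aromatic ring, or allyloxy to hydroxy.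

Compound 1 also carries the hydroxy and gives 80000 nM in this assay, so a number within the range of the assay is expected for compound 3. The reading of compound 3 may still stay at the limit. A modest step towards stronger inhibition is expected, with an estimated size of an at least 1.6-fold lower number from compound 2 to compound 3 (0.22 log units; that floor lies within the scatter). The estimate for compound 3 is 60000 nM, with an expected range from 25000 nM to 100000 nM.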

Compound 3, half-maximal inhibitory concentration: > 100000 nM
Compound 3 was reported as a limit (the forecaster's own chance of this, stated with the estimate: 35%); middle value at least 1.6-fold (0.22 log units) from the limit.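

In this assay compound 3 reads > 100000 nM, which is a limit and not a number. Within the data shown here, compound 2 also stands at a limit, so no step between these two compounds can be read. The compounds shown leave open whether allyloxy to hydroxy changes inhibition at all.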